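From a Chlorine to a Nitrile on the Benzyl Group

The source may report more compounds than this note shows. Statements on the series, on what has been measured and on what is new or still open speak of the compounds shown alone.

In a functional assay on QGY7701 cells (Homo sapiens) for cytotoxicity, read by MTT assay, with a stated time of 48 h (on this read-out lower numbers stand for stronger inhibition and higher numbers for weaker inhibition), compound 1 `O=c1ccoc2cc(OCc3cn(Cc4cccc(Br)c4)nn3)ccc12` gives 17600 nM.
In this assay compound 2 `O=c1ccoc2cc(OCc3cn(Cc4ccccc4Cl)nn3)ccc12` gives 19700 nM.

Among the compounds with values here, compound 2 holds the higher of the two numbers, yet its only neighbour lies within the scatter: a 1.1-fold higher number from compound 1 to compound 2 (0.05 log units; within the scatter). Compound 3 `N#Cc1ccc(Cn2cc(COc3ccc4c(=O)ccoc4c3)nn2)cc1` carries 4-cyanophenyl in place of 2-chlorophenyl on a saturated chain carbon bound to an aromatic nitrogen. Within the data shown here, the single measured step swapped one halogen-bearing ring for another and moved nothing beyond the scatter; a nitrile entering in place of chlorine has no measured counterpart here. Among the measured compounds shown here, with no step of the same kind to lean on, the expected change is a 1.0-fold higher number from compound 2 to compound 3 (0.01 log units; within the scatter), none beyond the scatter. Compound 3 is therefore estimated at 20000 nM, within 8000 nM to 50000 nM.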

Compound 3, half-maximal inhibitory concentration: > 100000 nM
Compound 3: a limit, no number; the forecaster's own chance of this, stated with the estimate: 10%; middle value at least 5.0-fold (0.69 log units) away from the limit.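

In this assay compound 3 gives a limit and not a number, the only such value among the compounds shown: the limit of > 100000 nM in this assay, at which 1 of the 3 values shown sits.

Where the two halogen-bearing rings had stayed within the scatter of each other, this place, on a saturated chain carbon bound to an aromatic nitrogen, now shows a change beyond it: an at least 5.0-fold higher number from compound 2 to compound 3 (0.70 log units; beyond the scatter), and an at least 5.6-fold higher number from compound 1 to compound 3 (0.75 log units; beyond the scatter). The group held there therefore matters, and 4-cyanophenyl goes with weaker inhibition than either halogen-bearing ring.

On these data alone, how far compound 3 lies past its limit remains open. So does whether an amine or a carboxylic acid in place of the nitrile would read the same way.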